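Removing One Methoxy Group From Compound 1

The source may hold more compounds than are shown below. What is called first, only, known or untested is meant among the compounds shown, and "the series" means these compounds.

Compound 1 `COc1cc(-c2cc(/C=C/C(=O)c3ccc(N)cc3)[nH]n2)cc(OC)c1OC` was tested in a functional assay on OVCAR-4 cells (Homo sapiens) for inhibition, read by sulforhodamine B assay, with a stated time of 48 h (a higher number here means a weaker inhibitor of growth, a lower number a stronger inhibitor of growth), where compound 1 gives 1400 nM. Among the three measured compounds it stands second highest: compound 2 `COc1ccc(-c2cc(/C=C/C(=O)c3ccc(OC)c(OC)c3)[nH]n2)cc1` gives 590 nM, a lower number, while compound 3 `COc1cc(-c2cc(/C=C/C(=O)c3ccc(Cl)c(Cl)c3)[nH]n2)cc(OC)c1OC` gives 10800 nM. Going by the values given here, the only single-site step in this set is a 7.7-fold higher number from compound 1 to compound 3 (0.89 log units; beyond the scatter), which changes the group on the carbonyl carbon, not the ring altered here. Compound 4 `COc1ccc(-c2cc(/C=C/C(=O)c3ccc(N)cc3)[nH]n2)cc1OC` differs from compound 1 by hydrogen in place of methoxy on an aromatic carbon. Among the compounds with values here, no measured step involves removing a methoxy group, so the direction is uncertain; only a small step is expected, a 1.4-fold higher number from compound 1 to compound 4 (0.15 log units; within the scatter). Compound 4 is therefore estimated at 2000 nM, within the range 700 nM to 6000 nM.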

Compound 4, concentration for 50% growth inhibition: 2680 nM
Compound 4: middle estimate off by 1.3-fold (0.13 log units), on the low side, within the range that was stated.
By their numbers in this assay, from the lowest: compound 2; then compounds 1 and 4 (each within the scatter of the next); then compound 3.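

In this assay, hydrogen in place of this methoxy group gives a 1.9-fold higher number from compound 1 to compound 4 (0.28 log units; within the scatter) so compound 1 and compound 4 cannot be told apart, and this methoxy group is not needed to keep growth inhibition in the range of compound 1. Nothing available explains why the two compounds read alike. The compounds shown leave open whether an ethoxy group or an amine on this aromatic carbon would move the number beyond the scatter. They also leave open what replacing either remaining methoxy group with hydrogen would do.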